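The compounds below may be only part of what the source reports. "The series", "measured", "known", "first", "only" and "open" are said of these compounds alone.

Compound 1 `O=C1OC(c2cnc3ccccc3c2)CN1C1CCN(Cc2cc3ccccc3[nH]2)CC1`: < 50200 nM
Compound 2 `COc1ccc2nccc(C3CN(C4CCN(Cc5c[nH]c6ccccc56)CC4)C(=O)O3)c2c1`: < 50200 nM

In an in vitro functional assay on RBL cells for antagonist activity at C-C chemokine receptor type 8 (Homo sapiens), read by FLIPR and calcium flux (on this read-out higher numbers stand for weaker inhibition and lower numbers for stronger inhibition), compound 1 gives < 50200 nM, which is a limit of the assay and not a number. Compound 2 gives < 50200 nM in this assay, also a limit. Compound 2 thus stands at the limit of < 50200 nM in this assay, at which 2 of the 2 values shown sit, and no measured number separates the two compounds. Compound 3 `COc1ccc2nccc(C3CN(C4CCN(C)CC4)C(=O)O3)c2c1` differs from compound 2 by hydrogen in place of 1H-indol-3-yl on a saturated chain carbon bound to an amine nitrogen in a ring. For the measured compounds named here, no measured step covers this change. The step from compound 2 to compound 3 in this assay is expected to read a step that the limit leaves unreadable from compound 2 to compound 3, toward weaker inhibition. Compound 3 is estimated at 25000 nM in this assay, with a range of 3000 nM to 50200 nM.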

Compound 3, half-maximal inhibitory concentration: < 50200 nM
Compound 3 ended at the assay's limit; the forecaster's own chance of this, stated with the estimate: 55%; the middle value does not contradict the limit.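

For the compounds shown here, compound 2 and compound 3 both stand at a limit in this assay and no step between them can be read: the limit of < 50200 nM in this assay, at which 3 of the 3 values shown sit. The compounds shown leave open what number any of them would reach and whether swapping 1H-indol-3-yl for hydrogen changes inhibition.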